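Ring size on the amide-type nitrogen: cyclooctyl to cyclopropyl

The source may report more compounds than this note shows. Statements on the series, on what has been measured and on what is new or still open speak of the compounds shown alone.

Measured compounds in a functional assay on the whole organism for inhibition, with Mus musculus as the target, at a dose of 30 mg/kg by the oral route; a lower number here means less inhibition, a higher number more inhibition at the dose given (going by the name of the read-out):
compound 1, `O=C(NCCCOc1ccc2nc(O)ccc2c1)N(C1CCCCCC1)[C@H]1CCCC[C@@H]1O`, 69%;
compound 2, `O=C(NCCCOc1ccc2nc(O)ccc2c1)N(C1CCCCCCC1)[C@H]1CCCC[C@@H]1O`, 100%.

Compound 2 stands highest of the two numbers in this assay; its nearest neighbour is compound 1, and the step of a number 31 percentage points higher from compound 1 to compound 2 (beyond the scatter) lies beyond the scatter. Compound 3, `O=C(NCCCOc1ccc2nc(O)ccc2c1)N(C1CC1)[C@H]1CCCC[C@@H]1O`, is not yet measured. It differs from compound 2 in one place: cyclopropyl in place of cyclooctyl on an amide-type nitrogen. Going by the values given here, the only measured step that bears on this change is the one from cycloheptyl to cyclooctyl, a number 31 percentage points higher from compound 1 to compound 2 (beyond the scatter), which is large and runs upward as the ring on the amide-type nitrogen grows. Among the compounds with values here, compound 3 moves the other way, and much further, so a fall in this assay is expected because a number 31 percentage points higher from compound 1 to compound 2 (beyond the scatter) is the only guide and it points downward for a smaller ring, giving an expected step of a number 75 percentage points lower from compound 2 to compound 3 (beyond the scatter). Within the data shown here, only two compounds support this direction, so the range must stay wide. Compound 3 is estimated at 25%, between 0% and 60%.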

Compound 3, a percentage reported as inhibition, in the whole organism at one dose (the size of the read-out at that dose, not a potency): 100%
The estimate for compound 3 lay 75 percentage points below the measured number, and the stated range ends below it.
By their numbers in this assay, from the lowest: compound 1; then compounds 2 and 3 (each within the scatter of the next).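

In this assay, ring size on the amide-type nitrogen does not order the series: no change at the digits printed from compound 2 to compound 3 (within the scatter), so cyclopropyl and cyclooctyl are not separated at this dose. Against that pair, a number 31 percentage points higher from compound 1 to compound 3 (beyond the scatter), which sets compound 1 with its cycloheptyl group apart from both the smaller and the larger ring, so the earlier rise with ring size does not hold as a trend across the three compounds. No available data account for this uneven pattern.

Open, from the compounds shown here alone, is whether cyclopentyl or cyclohexyl on this nitrogen would group with compound 1 or with compound 2 and compound 3, and how an open-chain group such as isopropyl would compare. A single-dose read-out also leaves open whether compound 2 and compound 3 would separate at lower doses.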